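Cytotoxicity notes on triazole-linked diaryl ureas

A few compounds are considered here, and "the series" means these few. Any claim that something is new, unique, unknown or untested is made for them only; others in the source may bear on it.

Measured so far:
compound 1 `CC(C)c1cccc(-n2cc(COc3cccc(NC(=O)Nc4ccc(Cl)c(C(F)(F)F)c4)c3)nn2)c1` — 21400 nM
compound 2 `O=C(Nc1cccc(OCc2cn(-c3ccc(F)cc3)nn2)c1)Nc1ccc(Cl)c(C(F)(F)F)c1` — 4740 nM

Among the compounds with values here, in a toxicity assay on MRC5 cells (Homo sapiens) for inhibition, read by MTT assay, with a stated time of 72 h (on this read-out higher numbers stand for weaker inhibition and lower numbers for stronger inhibition), compound 1 gives 21400 nM, the highest of the two numbers at hand, with compound 2 as its only neighbour. Within the data shown here, the one measured step, a 4.5-fold lower number from compound 1 to compound 2 (0.65 log units; beyond the scatter), shows that exchanging the aryl group on the triazole nitrogen can move the number by a modest amount, beyond the scatter, toward lower values.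

Compound 3 `O=C(Nc1cccc(OCc2cn(-c3ccccc3C(F)(F)F)nn2)c1)Nc1ccc(Cl)c(C(F)(F)F)c1` is not yet measured. It differs from compound 1 by 2-(trifluoromethyl)phenyl in place of 3-isopropylphenyl on an aromatic nitrogen. Among the measured compounds shown here, this change touches the same position as the step from compound 1 to compound 2, so that step is the only one that bears on it; no step for a 2-(trifluoromethyl)phenyl group itself has been measured, and the direction is therefore uncertain. A modest lowering, or a change within the scatter, is expected: a 2.4-fold lower number from compound 1 to compound 3 (0.38 log units; beyond the scatter). For compound 3 the estimate is 9000 nM, with a range from 3000 nM to 30000 nM.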

Compound 3, half-maximal inhibitory concentration: 8230 nM
Beside the measured number, compound 3's estimate is 1.1-fold (0.04 log units) above it; low and high end bracket the measured number.
By their numbers in this assay, from the lowest: compounds 2 and 3 (each within the scatter of the next); then compound 1.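

In this assay, a second aryl group on the aromatic nitrogen also gives a lower number than 3-isopropylphenyl, with a 2.6-fold lower number from compound 1 to compound 3 (0.42 log units; beyond the scatter) in these notes, so the earlier drop with 4-fluorophenyl is no longer a single case. The two replacement groups are not separated by this read-out, as a 1.7-fold higher number from compound 2 to compound 3 (0.24 log units; within the scatter) stands within the scatter even though their substituents differ in kind and in place on the ring. Nothing at hand explains either step.

On these data alone, all three compounds carry a substituted phenyl ring on this nitrogen, so it remains open where an unsubstituted phenyl group would fall relative to these values. Also open, as far as these compounds go, is how a ring bearing an amine or a carboxylic acid, or a longer alkyl chain in place of the aryl group, would read here.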